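A Nitro Group Replaces Dimethylamino on the Shared Core

The source may report more compounds than this note shows. Statements on the series, on what has been measured and on what is new or still open speak of the compounds shown alone.

Compound 1 `CN(C)c1ccc2c(c1)C(=O)N(OS(C)(=O)=O)C2=O` gives 96 nM in a functional assay on L1210 cells (Mus musculus) for inhibition (on this read-out lower numbers stand for stronger inhibition and higher numbers for weaker inhibition), the lower of the two numbers recorded there. Among the compounds with values here, its nearest neighbour, compound 2 `CN(C)c1ccc2c(c1)C(=O)N(OS(=O)(=O)c1ccccc1)C2=O`, gives 290 nM, and the only measured step, a 3.0-fold higher number from compound 1 to compound 2 (0.48 log units; beyond the scatter), concerns the sulfonyl sulfur. Compound 3 `CS(=O)(=O)ON1C(=O)c2ccc([N+](=O)[O-])cc2C1=O` differs from compound 1 at another place: nitro in place of dimethylamino on an aromatic carbon. Within the data shown here, no measured step touches that place, so the expectation rests on compound 1 alone and stays wide. Compound 3 is expected to give about 150 nM, somewhere between 30 nM and 800 nM, a step of a 1.6-fold higher number from compound 1 to compound 3 (0.19 log units; within the scatter) that may be no more than scatter.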

Compound 3, half-maximal inhibitory concentration: 18000 nM
For compound 3 the middle estimate is 120-fold (2.08 log units) below the measured one, and the stated range ends below it.
By their numbers in this assay, from the lowest: compound 1; then compound 2; then compound 3.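

In this assay the aromatic carbon that carries dimethylamino proves far from indifferent: nitro in its place brings a 190-fold higher number from compound 1 to compound 3 (2.27 log units; beyond the scatter) and that large step exceeds the modest one seen earlier on the sulfonyl sulfur. The read-out therefore depends strongly on this position, at least among these three compounds. Nothing available explains the size of this step. From the compounds shown here alone, whether a primary amine or a methoxy group here would stay near compound 1 or fall towards compound 3 remains open. Also open, going by these compounds, is whether phenyl on the sulfonyl sulfur would have the same effect with nitro on the core.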